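The source may report more compounds than this note shows. Statements on the series, on what has been measured and on what is new or still open speak of the compounds shown alone.

Measured compounds:

Compound 1, `Cc1ccc2oc(=O)c(C(=O)Nc3ccccc3)cc2c1`, in an assay on cells for inhibition of Amine oxidase [flavin-containing] B (Homo sapiens), read by fluorescence and Amplex Red, using microsomes, with a stated time of 15 min (a higher number here means a weaker inhibitor, a lower number a stronger inhibitor), compound 1 gives 15.3 nM.
Compound 2, `Cc1cccc(NC(=O)c2cc3cc(C)ccc3oc2=O)c1`, in this assay compound 2 gives 7.52 nM.
Compound 3, `COc1ccc2occ(C(=O)Nc3ccccc3)c(=O)c2c1`, in this assay compound 3 gives 41.8 nM.

Compounds 1 and 2 share one core and differ at a single spot: methyl in place of hydrogen on an aromatic carbon. This single change brings a 2.0-fold lower number from compound 1 to compound 2 (0.31 log units; beyond the scatter), a modest but real gain in potency.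

Compound 3 is built on a different core, and the difference between the two cores is not broken down here. Of the three measured compounds it gives the highest number, so it is the weakest inhibitor among them.

Compound 4, `COc1ccc2occ(C(=O)Nc3cccc(C)c3)c(=O)c2c1`, has not yet been measured. It stands to compound 3 as compound 2 stands to compound 1: methyl in place of hydrogen on an aromatic carbon. The place of the change is described in the same words for both pairs, so this is the same change carried onto the other core.

The expectation for compound 4 rests on a single earlier observation: the step from compound 1 to compound 2 in this assay was a 2.0-fold lower number from compound 1 to compound 2 (0.31 log units; beyond the scatter). If the change behaves alike on the core of compound 3, the step from compound 3 to compound 4 is expected to be a 2.0-fold lower number from compound 3 to compound 4 (0.30 log units; within the scatter). One earlier step is thin ground, and the core is not the same, so the expected range is kept wide. Compound 4 is therefore estimated at 21 nM in this assay, with a likely range from 9 nM to 45 nM.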

Compound 4, half-maximal inhibitory concentration: 21.8 nM
The estimate for compound 4 lay 1.0-fold (0.02 log units) below the measured number; the range from low to high includes it.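

In this assay, going from phenyl to 3-methylphenyl on the core of compound 3 gives a 1.9-fold lower number from compound 3 to compound 4 (0.28 log units; within the scatter), so this step taken alone does not clearly separate the two compounds. Its meaning comes from the comparison with the earlier step, since the same small change on two different cores gave steps of matching size, no further apart than repeat measurements would be expected to fall: the same change on two cores in this assay, a 2.0-fold lower number (0.31 log units; beyond the scatter) from compound 1 to compound 2 and a 1.9-fold lower number (0.28 log units; within the scatter) from compound 3 to compound 4, 1.1-fold (0.03 log units) apart, within the scatter of two such steps. This shows that, for these two cores, the earlier step was a fair guide to the later one, but two pairs of compounds are too few to make this a rule, and the numbers do not show why the steps match or whether the match would hold on a third core.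

The compounds shown leave open whether the methyl would count for as much at any other place on the phenyl ring, since only one place appears here. They also leave open whether a larger or different group at that same place, such as a longer chain like ethyl, a chlorine atom, an amine or a carboxylic acid, would give matching steps on both cores.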